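The compounds below may be only part of what the source reports. "The series", "measured", "known", "first", "only" and "open" are said of these compounds alone.

Measured so far in an assay on cells (Oocyte) for inhibition of Voltage-dependent T-type calcium channel subunit alpha-1H (Homo sapiens), tested at 100 uM; on this read-out lower numbers stand for less inhibition and higher numbers for more inhibition at the one concentration tested (going by the name of the read-out):
- compound 1 `O=C(CN1CCN(C(=O)CCCCN2CCN(c3ccccc3)CC2)CC1)Nc1cccc(C(F)(F)F)c1`: compound 1 gives 53%
- compound 2 `CN1CCN(CCCCC(=O)N2CCN(CC(=O)Nc3cccc(C(F)(F)F)c3)CC2)CC1`: compound 2 gives < 1%, a limit rather than a number

Compound 2 stands at the limit of < 1% in this assay, at which 1 of the 2 values shown sits. Among the measured compounds shown here, the only measured step, a number at least 52 percentage points lower from compound 1 to compound 2 (beyond the scatter), follows methyl in place of phenyl on an amine nitrogen in a ring. Compound 3 `CCN1CCN(CCCCC(=O)N2CCN(CC(=O)Nc3cccc(C(F)(F)F)c3)CC2)CC1` differs from compound 2 by methyl in place of hydrogen on a saturated chain carbon bound to an amine nitrogen in a ring. That step bears only loosely on this change, which keeps the methyl-type substituent and merely extends it. For compound 3 the expected step is a number at least 2 percentage points higher from compound 2 to compound 3 (that floor lies within the scatter), not beyond the scatter. Compound 3 is estimated at 3%, between 0% and 12%, likely again at the limit.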

Compound 3, a percentage reported as inhibition, at one concentration (the size of the read-out at that concentration, not a potency): 23.6%
Compound 3: middle estimate off by 20.6 percentage points, on the low side; the measured number lies above the stated range.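

In this assay, the group on the amine nitrogen in a ring responds even to a change as small as methyl to ethyl, giving a number at least 22.6 percentage points higher from compound 2 to compound 3 (beyond the scatter). Ethyl does not match phenyl at this position, with a number 29.4 percentage points lower from compound 1 to compound 3 (beyond the scatter). From the compounds shown here alone, the reading for compound 2 is a limit, so the full size of the first step stays unknown: the limit of < 1% in this assay, at which 1 of the 3 values shown sits.

Going by these compounds, whether a propyl or benzyl group on this nitrogen would continue the rise remains open. So does whether phenyl's standing depends on its ring or simply on its carbon count, which a cyclohexyl group would separate.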